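A few compounds are considered here, and "the series" means these few. Any claim that something is new, unique, unknown or untested is made for them only; others in the source may bear on it.

In an ADME assay on liver for metabolic stability, with Liver microsome (Homo sapiens) as the target, read by LC-MS, using microsomes, with a stated time of 5 h (a higher number here means faster removal of the compound, a lower number slower removal), three compounds have results so far. Compound 1 `OC(c1ncccc1F)C1(c2ccc(Cl)c(Cl)c2)CCC1` reaches 833 mL/min/kg and compound 2 `O[C@]1(c2ccccn2)CC[C@@H](c2ccc(C(F)(F)F)cc2)C1` reaches 383 mL/min/kg while compound 3 `C[C@@]1(c2ccc(OC(F)(F)F)cc2)C[C@@](O)(c2ccccn2)CO1` stays at 66.7 mL/min/kg as its clearance. Compound 2 therefore stands in the middle, lower than compound 1 and higher than compound 3, and both gaps lie beyond the usual scatter of repeat measurements.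

Compound 4 `O[C@]1(c2ccccn2)CC[C@H](c2ccc(C(F)(F)F)cc2)C1` still awaits its result. It has the same atoms and bonds as compound 2 and differs only in configuration as drawn (the two compounds have the same atoms and bonds and differ only in configuration as drawn: 1 of 2 stereo elements differ; a stereocentre at a saturated ring carbon is drawn R in compound 2 and S in compound 4), with a stereocentre at a saturated ring carbon drawn R in compound 2 and S in compound 4. The three measured compounds differ in more than one place, so they give no direct guide to the effect of such a change. The expectation is therefore no shift beyond the scatter and no firm direction, with an estimated step of a 1.1-fold lower number from compound 2 to compound 4 (0.04 log units; within the scatter) that stays small. The estimate for compound 4 is 350 mL/min/kg within an expected range of 150 mL/min/kg to 800 mL/min/kg for now.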

Compound 4, clearance: 333 mL/min/kg
Compound 4: middle estimate off by 1.1-fold (0.02 log units), on the high side, within the range that was stated.
By their numbers in this assay, from the lowest: compound 3; then compounds 4 and 2 (each within the scatter of the next); then compound 1.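

The earlier compounds shown here differ in more than one place, so none of them could isolate a single change, but this pair can. In this assay, redrawing the stereocentre at a saturated ring carbon from R to S gives a 1.2-fold lower number from compound 2 to compound 4 (0.06 log units; within the scatter), so the two compounds cannot be told apart by their clearance. This comparison tests the configuration at that carbon alone, with nothing else to separate the pair: the fact that compounds 2 and 4 differ only in the configuration as drawn.

This single pair cannot show whether the same redrawing would be equally silent on the cores of compound 1 or compound 3, or at the other stereo element. It also leaves open how clearance would respond if a different group, such as an amine or a carboxylic acid, were placed on that saturated ring carbon.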